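Replacing a Chain Chloro with Propyl in a Dehydrogenase Inhibitor

The source may hold more compounds than are shown below. What is called first, only, known or untested is meant among the compounds shown, and "the series" means these compounds.

Of the compounds shown here, three have so far been measured in an assay for inhibition of 15-hydroxyprostaglandin dehydrogenase [NAD(+)] (Homo sapiens), read by fluorescence, with a stated time of 15 min, in the presence of a further agent that is not named here; on this read-out lower numbers stand for stronger inhibition and higher numbers for weaker inhibition. Compound 1 `CCC[S+]([O-])c1sc2ncccc2c1N` gives 151 nM in this assay. Compound 2 `Nc1c([S+]([O-])CCCCl)sc2nc(-c3cccs3)cc(-c3ccccc3)c12` gives 4 nM in this assay, the lowest of the three numbers. Compound 3 `CCCC[S+]([O-])c1nc2ccc(-c3cccs3)nc2s1` gives 1230 nM in this assay. Compound 2 therefore stands at the strong end of the set: its nearest neighbour is compound 1, and compound 3 lies furthest from it, with both gaps wider than the usual scatter of such measurements. No two of the measured compounds differ in only one place, so no single structural step can be read from them directly.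

Compound 4 `CCCCCC[S+]([O-])c1sc2nc(-c3cccs3)cc(-c3ccccc3)c2c1N` remains to be measured. It differs from compound 2 in a single place: propyl in place of chloro on a saturated chain carbon, three bonds along the chain from a sulfur Everything else in the structure of compound 2 is kept. For the measured compounds named here, no measured pair tests a change of this kind on its own, so the expectation rests only on the small size of the change and on its position at the far end of the chain. The account expects the step from compound 2 to compound 4 to be small, a 1.5-fold higher number from compound 2 to compound 4 (0.18 log units; within the scatter) in this assay, not beyond the scatter in either direction. For compound 4 the estimate is 6 nM with a range from 2 nM at the low end to 20 nM at the high end.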

Compound 4, half-maximal inhibitory concentration: 18 nM
Estimate against measurement, compound 4: 3.0-fold (0.48 log units) below; the range from low to high includes it.
By their numbers in this assay, from the lowest: compound 2; then compound 4; then compound 1; then compound 3.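

For the compounds shown here, this is the first step in the set that can be read on its own, and in this assay it comes out as a 4.5-fold higher number from compound 2 to compound 4 (0.65 log units; beyond the scatter), so the saturated chain carbon three bonds along the chain from a sulfur is not indifferent to what it carries. The step is modest, yet it shows that exchanging 3-chloropropyl for hexyl, with one chlorine leaving and three carbons entering and no hydrogen-bond donor or acceptor on either side, is enough to move the number beyond the usual scatter. No measurement at hand bears on the reason for this step.

The compounds shown leave open whether the step follows the loss of the chlorine or the gain in chain length, and a plain propyl chain on the core of compound 2 would pull those two apart. From the compounds shown here alone, how a terminal amine or a carboxylic acid at this same place would move the number, and in which direction, also remains open.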